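A few compounds are considered here, and "the series" means these few. Any claim that something is new, unique, unknown or untested is made for them only; others in the source may bear on it.

Measured compounds in a functional assay on MDA-MB-231 cells (Homo sapiens) for inhibition, read by MTT assay, with a stated time of 24 h, tested at 100 uM; a lower number here means less inhibition, a higher number more inhibition at the concentration tested (going by the name of the read-out):
- compound 1 `O=C(N/N=C/c1ccc(Cl)cc1)c1ccc(O[C@@H]2O[C@H](CO)[C@@H](O)[C@H](O)[C@H]2O)cc1`: compound 1 gives 2.26%
- compound 2 `CC(=O)OC[C@H]1O[C@@H](Oc2ccc(-c3nnc(C(C)C)o3)cc2)[C@H](OC(C)=O)[C@@H](OC(C)=O)[C@@H]1OC(C)=O`: compound 2 gives 11.9%

Compound 1 stands lowest of the two numbers in this assay. Its nearest neighbour is compound 2, whose number is higher, but the gap between the two values lies within the scatter, so no order between compound 1 and compound 2 can be read from them. Going by the values given here, the two compounds differ in more than one place, so no single step connects them; only their two values are known.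

Compound 3 `O=C(N/N=C/c1ccccc1)c1ccc(O[C@@H]2O[C@H](CO)[C@@H](O)[C@H](O)[C@H]2O)cc1` is not yet measured in this assay. It differs from compound 1 in one place: hydrogen in place of chloro on an aromatic carbon.

Among the compounds with values here, no step between measured compounds in this assay is available for this change, and compound 1 itself sits near the bottom of the read-out. The expectation is therefore no step beyond the scatter, in either direction, with the small remaining room downward limiting any fall.

Compound 3 is expected to give 3% in this assay, with a range from 0% to 14%. This estimate means a step of a number 0.7 percentage points higher from compound 1 to compound 3 (within the scatter) that stays inside the scatter.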

Compound 3, a percentage reported as inhibition, at one concentration (the size of the read-out at that concentration, not a potency): 3.56%
The estimate for compound 3 lay 0.6 percentage points below the measured number; measured number inside the range.
By their numbers in this assay, from the lowest: compounds 1, 3 and 2 (each within the scatter of the next).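

Going by these compounds alone, replacing 4-chlorophenyl with phenyl in this assay gives a number 1.3 percentage points higher from compound 1 to compound 3 (within the scatter), the first step that can be read at a single place. At this aromatic carbon, para to a large group, chloro and hydrogen cannot be told apart in this read-out, so the chlorine atom is not required for the small inhibition recorded for compound 1 and compound 3 on the shared core. This holds only for this pair and for this one concentration, and no measurement on hand bears on the reason for the result.

As far as these compounds go, whether any other group on this aromatic carbon, such as an amine, a carboxylic acid or a methoxy group, would give a step beyond the scatter remains open, as does whether the same carbon matters at all with a different group in place. Compound 2 differs from compound 1 and compound 3 in more than one place, so the parts of the structure that might set the level of inhibition in this assay also remain unresolved.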